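Carboxylic Acid Chain Replaces Ethynyl on the Amine

The compounds below may be only part of what the source reports. "The series", "measured", "known", "first", "only" and "open" are said of these compounds alone.

Three compounds have been measured in an assay on HEK293 cells for binding affinity to Substance-K receptor (Rattus norvegicus), read by FRET, tested at 10 uM; on this read-out higher numbers stand for more inhibition at the one concentration tested (going by the name of the read-out) and lower numbers for less inhibition:
compound 1, `N#CCN(Cc1ccc2ccccc2c1)Cc1ccccc1Br`, gives 0%.
compound 2, `N#CCN(C/C=C/c1ccccc1)Cc1ccccc1`, gives 0%.
compound 3, `C#CCN(Cc1ccccc1)Cc1ccc2ccccc2c1`, gives 0%.

Compound 3 stands level with compound 1 and compound 2 at the digits shown; the value of compound 1 is the nearest to it and that of compound 2 the furthest, yet neither gap exceeds the scatter. Nothing among these three separates one from another.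

Compound 4, `O=C(O)CCCCN(Cc1ccccc1)Cc1ccc2ccccc2c1`, has not yet been measured. It differs from compound 3 by 3-carboxypropyl in place of ethynyl on a saturated chain carbon bound to an amine nitrogen. Among the measured compounds shown here, no step between measured compounds is available, so there is no precedent for what a 3-carboxypropyl group does here. With all three measured values sitting together at the floor of the read-out, compound 4 is expected to stay close to them. The step of a number 4 percentage points higher from compound 3 to compound 4 (within the scatter) is estimated to be small, not beyond the scatter, and compound 4 is estimated at 4%, in the range 0% to 18%.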

Compound 4, a percentage reported as inhibition, at one concentration (the size of the read-out at that concentration, not a potency): 0%
Beside the measured number, compound 4's estimate is 4 percentage points above it, and the stated range covers the measured number.
By their numbers in this assay, from the lowest: compounds 1, 2, 3 and 4 (each within the scatter of the next).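

Replacing ethynyl with 3-carboxypropyl on a saturated chain carbon bound to an amine nitrogen gives no change at the digits printed from compound 3 to compound 4 (within the scatter) in this assay, so this one step adds a carboxylic acid, with its hydrogen-bond donor and acceptor, without lifting the reading. Compound 3 already sits at the bottom of the read-out, so a loss could not appear here, and the step shows only that this chain brings no detectable gain at the one concentration tested. No available evidence bears on this result.

Going by these compounds, it remains open whether a different group on this nitrogen, such as a primary amine, a primary amide or a longer chain ending in a tetrazole, would give a reading above the others. On these data alone, it is equally open whether any such group would behave differently on the core of compound 1, which carries a bromine on its benzyl ring.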